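The source may hold more compounds than are shown below. What is called first, only, known or untested is meant among the compounds shown, and "the series" means these compounds.

Measured compounds:
Compound 1 `Clc1ccc(C(Oc2ccc3cc(Br)ccc3c2)c2cnc(NCC3CCCCC3)s2)cc1`: in an ADME assay on HepG2 2.2.15 cells (Homo sapiens) for cytotoxicity (a higher number here means that more compound is tolerated, a lower number that less compound is tolerated), compound 1 gives "not toxic" (no number reported).
Compound 2 `CC(C)(C)C(=O)Nc1ncc(C(Oc2ccc3cc(Br)ccc3c2)c2ccc(Cl)cc2)s1`: in this assay compound 2 gives "not toxic" (no number reported).
Compound 3 `O=C(Nc1ncc(C(Oc2ccc3cc(Br)ccc3c2)c2ccc(Cl)cc2)s1)c1ccc(Br)cc1`: in this assay compound 3 gives > 50000 nM, which is a limit of the assay and not a number.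

Among the compounds with values here, compound 3 therefore stands at the upper edge of what this assay can report, and the other two entries carry no number at all, so no step between measured compounds can be drawn. The only firm point is the limit of > 50000 nM in this assay, at which 1 of the 3 values shown sits.

Compound 4 `CCc1ccc(S(=O)(=O)Nc2ncc(C(Oc3ccc4cc(Br)ccc4c3)c3ccc(Cl)cc3)s2)cc1` has not yet been measured in this assay. Its structure differs from compound 3 in one place: (4-ethylphenyl)sulfonyl in place of (4-bromophenyl)carbonyl on a nitrogen on an aromatic ring. Within the data shown here, with no measured step available, the expectation rests on the shared core and on the fact that all three measured compounds were tolerated. The step from compound 3 to compound 4 is expected to be a step that the limit leaves unreadable from compound 3 to compound 4, that is none beyond the scatter, most likely again ending at the limit. Compound 4 is estimated at 60000 nM, with a range from 20000 nM to 200000 nM.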

Compound 4, half-maximal cytotoxic concentration: > 50000 nM
Compound 4 was reported as a limit; the forecaster's own chance of this, stated with the estimate: 70%; the middle value does not contradict the limit.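

Compound 3 and compound 4 both end at a limit and not at a number in this assay, so no step between them can be read: the limit of > 50000 nM in this assay, at which 2 of the 4 values shown sit.

The compounds shown leave open whether the exchange on the nitrogen changes the tolerated concentration at all.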